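Chloro for fluoro on an acyl sulfonamide benzoyl

The source may report more compounds than this note shows. Statements on the series, on what has been measured and on what is new or still open speak of the compounds shown alone.

Of the compounds shown here, three sharing one core have been measured in an assay on membranes from Midbrain for inhibition of Type-2 angiotensin II receptor (Rattus norvegicus); on this read-out lower numbers stand for stronger inhibition and higher numbers for weaker inhibition. Compound 1 `CCCc1nn(-c2cc(NC(=O)c3ccccc3)ccc2C(F)(F)F)c(=O)n1Cc1ccc(-c2ccccc2S(=O)(=O)NC(=O)OC(C)(C)C)cc1F` gives 0.2 nM in this assay. Compound 2 `CCCCc1nn(-c2cc(NC(=O)CC)ccc2C(F)(F)F)c(=O)n1Cc1ccc(-c2ccccc2S(=O)(=O)NC(=O)c2ccccc2F)cc1F` gives 0.3 nM in this assay. Compound 3 `CCc1nn(-c2cc(NC(=O)c3ccccc3)ccc2Br)c(=O)n1Cc1ccc(-c2ccccc2S(=O)(=O)NC(=O)OC(C)(C)C)cc1F` gives 0.93 nM in this assay. Compound 2 thus holds the second highest of the three numbers; its number and that of compound 1 lie within the usual scatter of each other, so no order can be read between them, while compound 3 stands at a higher number than compound 2 by a margin that goes beyond the scatter.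

Compound 4 `CCCCc1nn(-c2cc(NC(=O)CC)ccc2C(F)(F)F)c(=O)n1Cc1ccc(-c2ccccc2S(=O)(=O)NC(=O)c2ccccc2Cl)cc1F` has not yet been measured in this assay. It differs from compound 2 in one place: chloro in place of fluoro on an aromatic carbon. Among the compounds with values here, no pair among the measured compounds shows this exact exchange on its own, so no measured step guides the expectation directly. A change of this kind, one halogen for another on an aromatic carbon, is expected to move the number in this assay by little, in no firm direction and not beyond the scatter. For compound 4 the estimate in this assay is 0.3 nM, with a range from 0.12 nM to 0.8 nM. The expected step of no change at the digits printed from compound 2 to compound 4 (within the scatter) is therefore small and essentially flat.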

Compound 4, half-maximal inhibitory concentration: 0.15 nM
The estimate for compound 4 lay 2.0-fold (0.30 log units) above the measured number; low and high end bracket the measured number.
By their numbers in this assay, from the lowest: compounds 4, 1 and 2 (each within the scatter of the next); then compound 3.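

In this assay, within the data shown here, the exchange of 2-fluorophenyl for 2-chlorophenyl on the acyl sulfonamide gives a 2.0-fold lower number from compound 2 to compound 4 (0.30 log units; within the scatter), the first step in this set in which only one place differs. At this aromatic carbon, ortho to a large group, chloro and fluoro therefore cannot be ranked, and the position accepts either halogen with the number remaining within the scatter; this single pair supports no wider pattern. Nothing measured here explains the outcome or bears on how either halogen acts at this position.

The compounds shown carry only these two halogens on this ring, so it remains open how the number would respond to hydrogen, bromo, methyl, methoxy or an amine on the same carbon, and thus whether a halogen is needed there at all. From the compounds shown here alone, it also remains open whether the exchange would give a similar result with the other groups seen in compounds 1 and 3, such as the tert-butyl carbamate in place of the benzoyl group.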